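Nitrophenyl isomers on the sulfonyl sulfur

This account rests on a few compounds, and the source may have more. Where it says the series, first, only, none or still open, it means among the compounds named here.

Of the compounds shown here, three have been read in a functional assay on RS4-11 cells (Homo sapiens) for inhibition, read by CCK-8 assay, with a stated time of 48 h, tested at 20 uM; on this read-out lower numbers stand for less inhibition of growth and higher numbers for more inhibition of growth at the one concentration tested. Compound 1 (`N#C/C(=C\c1ccccc1OS(=O)(=O)c1ccccc1[N+](=O)[O-])C(=O)Nc1nnc(Cc2cccc3ccccc23)s1`) gives 66%, and compound 2 (`COc1ccc(S(=O)(=O)Oc2ccccc2/C=C(\C#N)C(=O)Nc2nnc(Cc3ccccc3)s2)cc1`) gives 78%. Compound 3 (`N#C/C(=C\c1ccccc1OS(=O)(=O)c1ccc([N+](=O)[O-])cc1)C(=O)Nc1nnc(Cc2ccccc2)s1`) gives 57%, which lies within the scatter of compound 1 and beyond the scatter under compound 2.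

The next comparison is with compound 4 (`N#C/C(=C\c1ccccc1OS(=O)(=O)c1ccccc1[N+](=O)[O-])C(=O)Nc1nnc(Cc2ccccc2)s1`), not yet measured. The change is 2-nitrophenyl in place of 4-nitrophenyl on a sulfonyl sulfur, with the same atoms joined differently.

For the measured compounds named here, only one measured step touches this part of the molecule: a number 21 percentage points lower from compound 2 to compound 3 (beyond the scatter), with nitro in place of methoxy. It is modest but beyond the scatter. That step exchanges the group and does not relocate it, so it gives only indirect guidance. Compound 1 carries the same 2-nitrophenyl on its sulfonyl sulfur and gives 66%, but it differs from compound 4 elsewhere. Going by the values given here, no measured pair isolates the change in nitro position.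

The step expected in this assay is therefore a number 3 percentage points higher from compound 3 to compound 4 (within the scatter), which is no shift beyond the scatter. For compound 4 the estimated value is 60%, with an expected range from 45% to 75%.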

Compound 4, percent growth inhibition at one concentration: 71%
Estimate against measurement, compound 4: 11 percentage points below; low and high end bracket the measured number.
By their numbers in this assay, from the lowest: compounds 3, 1, 4 and 2 (each within the scatter of the next, the first and the last beyond it).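

Within this assay, 2-nitrophenyl in place of 4-nitrophenyl on a sulfonyl sulfur gives a number 14 percentage points higher from compound 3 to compound 4 (beyond the scatter), so with the same atoms joined differently this position responds to where the nitro group stands, and not only to which group is present. The lower number seen for nitro in place of methoxy therefore does not hold for every nitro isomer: compound 4 goes against that reading, with a number 7 percentage points lower from compound 2 to compound 4 (within the scatter) for 2-nitrophenyl in place of 4-methoxyphenyl, while phenyl in place of naphthalen-1-yl at the other end of the molecule gives a number 5 percentage points higher from compound 1 to compound 4 (within the scatter) and so separates nothing with 2-nitrophenyl on the sulfonyl sulfur. Nothing available accounts for the isomer step.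

Still open is whether that step carries over when naphthalen-1-yl replaces phenyl, as compound 1 has no 4-nitrophenyl partner among the compounds shown. Also open, going by these compounds, is what an amine or a carboxylic acid on the aromatic ring attached to the sulfonyl sulfur would give, and how any of these growth-inhibition numbers at a single concentration would translate into a full concentration response.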